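A few compounds are considered here, and "the series" means these few. Any claim that something is new, unique, unknown or untested is made for them only; others in the source may bear on it.

This account follows cytotoxicity, measured in an ADME assay on RD cells (Homo sapiens) for cytotoxicity, read by MTT assay, with a stated time of 24 h (a higher number here means that more compound is tolerated, a lower number that less compound is tolerated), across a small set of compounds built on a shared core. Compound 1 `Cc1cc(-c2noc(C(F)(F)F)n2)cc(C)c1OCCC(C)CCN1CCN(c2ccnc(N)c2)C1=O` opens the set. In this assay compound 1 gives > 100000 nM, which is a limit of the assay rather than a number. Compound 2 `CC(CCOc1ccc(-c2noc(C(C)(C)C)n2)cc1)CCN1CCN(c2ccnc(N)c2)C1=O` is the next member, and in this assay compound 2 gives 55000 nM. Compound 3 `CCO/N=C/c1ccc(OCCCCCN2CCN(c3ccnc(N)c3)C2=O)cc1` completes the measured group, and in this assay compound 3 gives 59000 nM. Of the two numbers shown, compound 2 has the lower one, but its gap to compound 3 lies within the scatter, so the two cannot be told apart on this evidence.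

Compound 4 `CCc1nc(-c2ccc(OCCC(C)CCN3CCN(c4ccnc(N)c4)C3=O)cc2)no1` has not yet been measured. It differs from compound 2 by a single change: ethyl in place of tert-butyl on an aromatic carbon. Going by the values given here, no measured pair isolates this change, so there is no direct precedent to lean on. With compound 2 giving 55000 nM and compound 3 giving 59000 nM, the exchange of one alkyl group is expected to move this assay little, in no clear direction. The estimated step is a 1.2-fold higher number from compound 2 to compound 4 (0.07 log units; within the scatter), which stays within the scatter. Compound 4 is expected to give 65000 nM, with a range from 30000 nM to 130000 nM.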

Compound 4, half-maximal cytotoxic concentration: > 100000 nM
Compound 4: a limit, no number (the forecaster's own chance of this, stated with the estimate: 30%); middle value at least 1.5-fold (0.18 log units) away from the limit.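

Ethyl in place of tert-butyl on this aromatic carbon gives the first pair in the set that differs in one place, and in this assay the change reads as an at least 1.8-fold higher number from compound 2 to compound 4 (0.25 log units; that floor lies within the scatter). That floor lies within the scatter, so the pair shows no firm shift on its own, yet it does show that removing carbon from this group at least does not bring the reading down. Compound 4 gives a limit and not a number, so the true size of the step cannot be read: the limit of > 100000 nM in this assay, at which 2 of the 4 values shown sit.

The compounds shown leave open how methyl, cyclopropyl or an amine on this same carbon would read in this assay, and so whether the reading follows the size of the group at all. Going by these compounds, compound 1 carries trifluoromethyl on this carbon but also differs elsewhere, so it cannot be compared directly with compound 2 or compound 4, and whether the change from tert-butyl to ethyl would read the same on a different substitution of the shared core also stays open.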